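This account rests on a few compounds, and the source may have more. Where it says the series, first, only, none or still open, it means among the compounds named here.

- Compound 1 `CC(=O)N1N=C(c2ccc3ccccc3c2)OC1c1ccc(Br)cc1`: 4.68 ug/mL
- Compound 2 `CC(=O)N1N=C(c2ccc3ccccc3c2)OC1c1ccccc1F`: 6.05 ug/mL
- Compound 3 `CC(=O)N1N=C(c2ccc3ccccc3c2)OC1c1ccc(F)cc1`: 4.65 ug/mL

These values come from a functional assay on B16-F10 cells (Mus musculus) for antiproliferative activity, read by MTT assay, with a stated time of 48 h; a higher number here means a weaker inhibitor, a lower number a stronger inhibitor. Compound 3, at 4.65 ug/mL, stands level with compound 1 and within the scatter of compound 2. Compound 4 `CC(=O)N1N=C(c2ccc3ccccc3c2)OC1c1ccccc1O` carries 2-hydroxyphenyl in place of 4-fluorophenyl on a saturated ring carbon. Among the measured compounds shown here, no measured step brings in 2-hydroxyphenyl, so the closest evidence is the three exchanges among the other aryl groups: a 1.3-fold higher number from compound 1 to compound 2 (0.11 log units; within the scatter), a 1.0-fold lower number from compound 1 to compound 3 (0.00 log units; within the scatter) and a 1.3-fold lower number from compound 2 to compound 3 (0.11 log units; within the scatter). As far as these compounds go, all three lie within the scatter, so no step beyond the scatter is expected in this assay, though this new group remains untested. The expected change is a 1.2-fold higher number from compound 3 to compound 4 (0.07 log units; within the scatter). For compound 4 the estimated value is 5.5 ug/mL, with an expected range of 2.7 ug/mL to 11 ug/mL.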

Compound 4, half-maximal inhibitory concentration: 2.58 ug/mL
Estimate against measurement, compound 4: 2.1-fold (0.33 log units) above; measured number below the stated range.
By their numbers in this assay, from the lowest: compounds 4, 3, 1 and 2 (each within the scatter of the next, the first and the last beyond it).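

In this assay, among the compounds shown here, 2-hydroxyphenyl gives the first exchange at this saturated ring carbon to pass the scatter, though against one compound only, where hydroxy replaces fluoro on the aromatic carbon (a 2.3-fold lower number from compound 2 to compound 4 (0.37 log units; beyond the scatter)). The other two steps stay within the scatter (a 1.8-fold lower number from compound 3 to compound 4 (0.26 log units; within the scatter); a 1.8-fold lower number from compound 1 to compound 4 (0.26 log units; within the scatter)), so this group, with its hydrogen-bond donor, is tolerated here but is not clearly set apart from every halogenated aryl group. The compounds shown leave open whether a methoxy or an amine in place of the hydroxy would keep this number. No measurement shown here accounts for the result.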